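The source may report more compounds than this note shows. Statements on the series, on what has been measured and on what is new or still open speak of the compounds shown alone.

Compounds measured so far:
- compound 1 `COc1c(/C=C2/C(=O)Nc3ccc(Cl)cc32)c2ccccc2n1-c1ccccc1`: 6310 nM
- compound 2 `COc1cc2c(cc1C)NC(=O)/C2=C/c1c(Cl)n(Cc2cc(OC)c(OC)c(OC)c2)c2cc(C)c(OC)cc12`: 16600 nM
- compound 3 `O=C1/C(=C/c2c(Cl)[nH]c3ccccc23)c2ccccc2N1Cc1ccccc1`: 4170 nM

In a functional assay on cells (Cancer cell lines, Homo sapiens) for cytotoxicity, with a stated time of 48 h (a higher number here means a weaker inhibitor of growth, a lower number a stronger inhibitor of growth), compound 2 stands at the highest of the three numbers; compound 1 gives 6310 nM and compound 3 gives 4170 nM, and both of those gaps to compound 2 lie beyond the scatter. Compound 4 `COc1ccc2c(c1)/C(=C\c1c(Cl)n(Cc3cc(OC)c(OC)c(OC)c3)c3cc(C)c(OC)cc13)C(=O)N2` is not yet measured. It differs from compound 2 in one place: hydrogen in place of methyl on an aromatic carbon. Among the compounds with values here, no pair of measured compounds isolates this change, so nothing here shows what the loss of the methyl does. The expected step in this assay is therefore none beyond the scatter, in either direction. For compound 4 the estimated value is 14000 nM, with a range from 5000 nM to 40000 nM. This estimate amounts to a step of a 1.2-fold lower number from compound 2 to compound 4 (0.07 log units; within the scatter), expected to stay within the scatter.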

Compound 4, concentration for 50% growth inhibition: 11000 nM
Estimate against measurement, compound 4: 1.3-fold (0.10 log units) above; the range from low to high includes it.
By their numbers in this assay, from the lowest: compounds 3, 1, 4 and 2 (each within the scatter of the next, the first and the last beyond it).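

In this assay, hydrogen in place of methyl on an aromatic carbon ortho to a methoxy group gives a 1.5-fold lower number from compound 2 to compound 4 (0.18 log units; within the scatter) and so leaves the number within the scatter. Within the data shown here, this is the first pair to isolate this change, and it shows that in this compound the methyl at this position can give way to hydrogen without a step beyond the scatter. No evidence bears on this result.

On these data alone, whether an amine or a carboxylic acid on this aromatic carbon would give a step beyond the scatter stays open. So does whether the same change would read alike in the cores of compound 1 and compound 3.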